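Epimer of compound 1 at the chain stereocentre

The compounds below may be only part of what the source reports. "The series", "measured", "known", "first", "only" and "open" are said of these compounds alone.

The series is followed in a functional assay on HeLa cells (Homo sapiens) for inhibition, read by MTT assay, with a stated time of 72 h; on this read-out higher numbers stand for weaker inhibition and lower numbers for stronger inhibition. Going by the values given here, compound 1 `CO[C@@H]1[C@H]2OC(=O)C[C@H]2O[C@@H]1[C@@H](OC)c1ccccc1` gives 89300 nM, the highest of the three numbers so far; the nearest to it, compound 2 `CO[C@@H]1[C@H]2OC(=O)C[C@H]2O[C@@H]1[C@@H](O)c1ccccc1`, gives 11000 nM, and the furthest, compound 3 `O=C1C[C@H]2O[C@H](C(O)O)[C@H](O)[C@H]2O1`, gives 890 nM. Among the compounds with values here, the only measured step between compounds that differ in one place is an 8.1-fold lower number from compound 1 to compound 2 (0.91 log units; beyond the scatter), in which hydrogen stands in place of methyl on an oxygen on a saturated carbon.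

Compound 4 `CO[C@@H]1[C@H]2OC(=O)C[C@H]2O[C@@H]1[C@H](OC)c1ccccc1` is to be measured in this assay. It differs from compound 1 thus: the two compounds have the same atoms and bonds and differ only in configuration as drawn: 1 of 5 stereo elements differ; a stereocentre at a saturated chain carbon is drawn S in compound 1 and R in compound 4. Within the data shown here, no measured pair changes configuration alone, so the step from compound 1 to compound 2 does not bear directly on this change; it shows only that an alteration of the substituent on that chain carbon can move the number beyond the scatter. With nothing in the data to set direction or size for an inversion, the expectation for compound 4 is a step of a 1.0-fold lower number from compound 1 to compound 4 (0.00 log units; within the scatter), that is, no change beyond the scatter, carried with a wide range. Compound 4 is therefore estimated at 89000 nM, between 25000 nM and 300000 nM.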

Compound 4, half-maximal inhibitory concentration: 56400 nM
For compound 4 the middle estimate is 1.6-fold (0.20 log units) above the measured one; low and high end bracket the measured number.
By their numbers in this assay, from the lowest: compound 3; then compound 2; then compounds 4 and 1 (each within the scatter of the next).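

Going by these compounds alone, this is the first pair that isolates configuration at the saturated chain carbon, with nothing else altered: the fact that compounds 1 and 4 differ only in the configuration as drawn. In this assay the inversion gives a 1.6-fold lower number from compound 1 to compound 4 (0.20 log units; within the scatter), so with the methyl ether in place, drawing this carbon S or R makes no difference that the assay can resolve. The only single-place step beyond the scatter remains an 8.1-fold lower number from compound 1 to compound 2 (0.91 log units; beyond the scatter), so among the single-place changes shown, replacing methyl with hydrogen on an oxygen moves the number, whereas inverting the chain stereocentre does not.

Going by these compounds, the hydroxyl of compound 2 appears in one configuration only, so it remains open whether inversion at this carbon would also leave the number within the scatter when the methyl is absent. The compounds shown also do not tell how an amine or a longer ether chain on this carbon would behave in either configuration, or whether the result for compound 4 holds for substituents other than the methyl ether.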